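The source may report more compounds than this note shows. Statements on the series, on what has been measured and on what is new or still open speak of the compounds shown alone.

Of the compounds shown here, two have been measured in an assay on H4 cells for inhibition of Fatty-acid amide hydrolase 1 (Homo sapiens); on this read-out higher numbers stand for weaker inhibition and lower numbers for stronger inhibition. Compound 1 `CCCCOc1ccc(C(CC)NC(=O)Oc2ccc(F)cc2F)cc1` gives 21 nM in this assay. Compound 2 `CCCCOc1ccc(CNC(=O)Oc2cccc(Cl)c2)cc1` gives 12 nM in this assay, the lowest of the two numbers, yet the gap to compound 1 falls within the usual scatter of repeated measurements, so nothing separates the two. Compound 3 `CCCCOc1ccc(CNC(=O)Oc2ccc(F)cc2F)cc1` has not yet been measured. It differs from compound 2 in one place: 2,4-difluorophenyl in place of 3-chlorophenyl on an oxygen next to a carbonyl group. Going by the values given here, no pair of measured compounds shows this change on its own, so its size is not known from the data. Compound 1 carries the same 2,4-difluorophenyl on the oxygen next to the carbonyl group and gives 21 nM, near compound 2. Across this change the step is expected to be small, a 1.3-fold higher number from compound 2 to compound 3 (0.10 log units; within the scatter), with no direction beyond the scatter. Compound 3 is therefore estimated at 15 nM, within a range from 6 nM to 40 nM.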

Compound 3, half-maximal inhibitory concentration: 8.7 nM
The estimate for compound 3 lay 1.7-fold (0.24 log units) above the measured number; measured number inside the range.
By their numbers in this assay, from the lowest: compounds 3, 2 and 1 (each within the scatter of the next, the first and the last beyond it).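

On an oxygen next to a carbonyl group, 2,4-difluorophenyl in place of 3-chlorophenyl gives a 1.4-fold lower number from compound 2 to compound 3 (0.14 log units; within the scatter) in this assay, so this read-out does not tell the two groups apart. Going by these compounds alone, compound 3 also allows the first reading at the saturated chain carbon bound to an amide-type nitrogen and an aromatic carbon, where hydrogen in place of ethyl gives a 2.4-fold lower number from compound 1 to compound 3 (0.38 log units; beyond the scatter), a modest step and the only one here beyond the scatter. Nothing measured here explains either step.

On these data alone, each change is seen in a single pair, so whether either step holds on a different core remains open. Also open, as far as these compounds go, is where a methyl on that chain carbon would fall, and how an amine or a carboxylic acid on the oxygen-bound ring would read.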